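The source may hold more compounds than are shown below. What is called first, only, known or untested is meant among the compounds shown, and "the series" means these compounds.

Measured compounds:
- compound 1, `C/N=C(\S)CCn1nc(-c2ccccc2)ccc1=O`: 68.2%
- compound 2, `Cc1ccc(=O)n(CC(=N)S)n1`: 31.5%
- compound 3, `C/N=C(\S)CCn1ncccc1=O`: 35.7%

These three compounds were tested in a functional assay on the whole organism (stomach) for inhibition, with Rattus norvegicus as the target, at a dose of 100 mg/kg by the intraduodenal route; on this read-out lower numbers stand for less inhibition and higher numbers for more inhibition at the one dose given (going by the name of the read-out). On the numbers shown, compound 1 stands highest of the three, with compound 3 nearest and compound 2 furthest from it. Among the measured compounds shown here, the one change that can be followed across a single step is the loss of the phenyl group: a number 32.5 percentage points lower from compound 1 to compound 3 (beyond the scatter), a step that lies well beyond the scatter of this assay. Compound 2, which also lacks the phenyl, sits near compound 3.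

The compound not yet measured is compound 4, `CC(Cn1nc(-c2ccccc2)ccc1=O)C(=N)S`. It differs from compound 1 as follows: a group of 5 heavy atoms (3 carbon, 1 nitrogen, 1 sulfur; no ring) in place of a group of 5 heavy atoms (3 carbon, 1 nitrogen, 1 sulfur; no ring), on a saturated chain carbon bound to an aromatic nitrogen. The phenyl group on the core is kept in compound 4; only the chain bound to the aromatic nitrogen is built differently from the same atoms.

For the measured compounds named here, no measured step follows a change of this kind, so the comparison rests on the fact that compound 4 keeps the phenyl group whose removal gave the large step from compound 1 to compound 3. On that basis the expectation for compound 4 is a number near that of compound 1, with a modest and uncertain shift downward: a number 13.2 percentage points lower from compound 1 to compound 4 (beyond the scatter). The estimate for compound 4 in this assay is 55%, within a range from 30% to 80%.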

Compound 4, a percentage reported as inhibition, in the whole organism at one dose (the size of the read-out at that dose, not a potency): 86.4%
Estimate against measurement, compound 4: 31.4 percentage points below; measured number outside the range, above it.
By their numbers in this assay, from the lowest: compounds 2 and 3 (each within the scatter of the next); then compound 1; then compound 4.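

In this assay, among the compounds shown here, the earlier compounds showed only that the phenyl group on the core counts, whereas this first step at the chain shows that the chain counts too: the same atoms, joined differently on a saturated chain carbon bound to an aromatic nitrogen, give a number 18.2 percentage points higher from compound 1 to compound 4 (beyond the scatter). The chain of compound 1 is therefore not the highest-scoring arrangement among those shown, and the change moves the number up, while the only earlier single step moved it down. The two chains match in heavy atoms, yet the entering group counts 2 hydrogen-bond donors where the leaving group counts 1, and no measurement here connects that difference or any other feature of the rearrangement to the higher number.

The compounds shown leave open whether the rearranged chain would give a similar rise without the phenyl group, and whether a longer chain, or an amine or a carboxylic acid in place of the sulfur-bearing end, would keep it. Since each number comes from one dose, they also leave open whether compound 4 stays ahead of compound 1 at other doses.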